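The source may hold more compounds than are shown below. What is called first, only, known or untested is meant among the compounds shown, and "the series" means these compounds.

Compound 1 `COc1ccc(OC)c(/C=C/c2nnc(Nc3ccc(Cl)cc3)o2)c1` and compound 2 `COc1ccc(OC)c(/C=C/C(=O)N/N=C/c2ccc(Cl)cc2)c1` were both tested in a functional assay on COLO 205 cells (Homo sapiens) for antiproliferative activity, read by sulforhodamine B assay, with a stated time of 48 h; on this read-out higher numbers stand for lower toxicity in this test and lower numbers for higher toxicity in this test. Compound 1 reaches only the limit of this assay, > 100000 nM, and so carries no number. Compound 2 gives 63900 nM in this assay. That is the only numerical result among the two; the other sits at a limit (the limit of > 100000 nM in this assay, at which 1 of the 2 values shown sits), so compound 2 cannot be ranked against a second number. Compound 3 `COc1ccc(OC)c(/C=C/C(=O)N/N=C/c2ccccc2)c1` has not yet been measured. It differs from compound 2 in one place, (hydrogen in place of chloro on an aromatic carbon), that is, hydrogen in place of chloro on an aromatic carbon. Within the data shown here, no measured pair shows what such a change does. The step of a 1.3-fold higher number from compound 2 to compound 3 (0.10 log units; within the scatter) is expected to be small, not beyond the usual scatter, leaning if anything toward lower toxicity. Compound 3 is therefore expected to give about 80000 nM, most likely between 30000 nM and 200000 nM.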

Compound 3, concentration lethal to 50% of the cells: > 100000 nM
Compound 3: only a limit was reported; the forecaster's own chance of this, stated with the estimate: 40%; middle value at least 1.2-fold (0.09 log units) away from the limit.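

Among these compounds, this pair gives the first direct look at this position on the ring, where hydrogen replaces chloro, a change from 4-chlorophenyl to phenyl. The comparison shows an at least 1.5-fold higher number from compound 2 to compound 3 (0.19 log units; that floor lies within the scatter), so the floor alone does not show a real difference, although the true step could be larger. Chloro is thus the only group at this position so far with a measured number in this assay, while compound 3 gives > 100000 nM, which is a limit and not a number.

From the compounds shown here alone, the true size of the step stays unknown because the value for compound 3 is a limit, and such limits are common in this small set: the limit of > 100000 nM in this assay, at which 2 of the 3 values shown sit. It also remains open how a different group on that aromatic carbon, such as an amine or a carboxylic acid, would behave.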